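Chloro in Place of Cyano on Two Related Cores

The source may hold more compounds than are shown below. What is called first, only, known or untested is meant among the compounds shown, and "the series" means these compounds.

Compound 1 `Clc1ccc(-c2cc3n(n2)CCCC3)nc1`: in a functional assay on HEK293 cells for negative allosteric modulation of metabotropic glutamate receptor 5 (Rattus norvegicus), read by FLIPR and calcium flux, with a stated time of 170 s (on this read-out higher numbers stand for weaker inhibition and lower numbers for stronger inhibition), compound 1 gives 669 nM.
Compound 2 `N#Cc1ccc(-c2cc3n(n2)CCCC3)nc1`: in this assay compound 2 gives > 10000 nM, which is a limit of the assay and not a number.
Compound 3 `N#Cc1ccc(COc2cc3n(n2)CCCC3)nc1`: in this assay compound 3 gives 316 nM.

Compound 1 and compound 2 share a core and differ in one place: chloro in place of cyano on an aromatic carbon. That change brings an at least 14-fold lower number from compound 2 to compound 1 (1.17 log units; beyond the scatter). The step is open at one end, as the starting value is the limit of > 10000 nM in this assay, at which 1 of the 3 values shown sits. Compound 3 carries the same cyano group on a different core; the difference between the two cores is not broken down here. Compound 3 shows a lower number than compound 1.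

Compound 4 `Clc1ccc(COc2cc3n(n2)CCCC3)nc1` has not yet been measured. It comes from compound 3 by chloro in place of cyano on an aromatic carbon, the same kind of change as from compound 2 to compound 1, though here the place is para to a large group rather than para to a group of 9 heavy atoms. In this assay compound 4 is expected near 120 nM, roughly between 30 nM and 600 nM. The expected step, a 2.6-fold lower number from compound 3 to compound 4 (0.42 log units; beyond the scatter), is smaller than the measured one, since compound 3 already gives 316 nM. The measured step, by contrast, starts from the limit of compound 2 and is open at one end.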

Compound 4, half-maximal inhibitory concentration: 1550 nM
Estimate against measurement, compound 4: 13-fold (1.11 log units) below, and the stated range ends below it.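

On the core of compound 3, putting chloro in place of cyano brings a 4.9-fold higher number from compound 3 to compound 4 (0.69 log units; beyond the scatter), the opposite direction to the step on the core of compound 1. The change therefore does not carry over from one of these cores to the other, and its effect on one core gives a poor guide to its effect on the other: the same change on two cores in this assay, an at least 14-fold lower number (1.17 log units; beyond the scatter) from compound 2 to compound 1 and a 4.9-fold higher number (0.69 log units; beyond the scatter) from compound 3 to compound 4, at least 73-fold (1.86 log units) apart, beyond the scatter of two such steps

With only two pairs, this does not show why the direction reverses or what the change would do on a third core, and the earlier step has no exact size, as compound 2 carries a limit and not a number: the limit of > 10000 nM in this assay, at which 1 of the 4 values shown sits.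

The compounds shown leave open how other groups on the same aromatic carbon, such as fluoro, methyl or methoxy, would read on each core. They also leave open whether the reversal would persist with an amine in place of the ether oxygen of compound 3 and compound 4.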